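Chain lengthening of hydroxamate tails on two cores

The compounds below may be only part of what the source reports. "The series", "measured", "known", "first", "only" and "open" are said of these compounds alone.

Four hydroxamic acids are compared in a functional assay on MCF7 cells (Homo sapiens) for inhibition, read by MTT assay, with a stated time of 72 h; a higher number here means a weaker inhibitor, a lower number a stronger inhibitor. Compound 1 `Nc1ncnc2c1c(-c1cnc3[nH]ccc3c1)nn2CCCCCC(=O)NO` and compound 2 `Nc1ncnc2c1c(-c1cnc3[nH]ccc3c1)nn2CCCCCCC(=O)NO` share one core and differ only in the tail. For compound 1 this assay reports only a limit, > 150000 nM. Compound 2 gives 19800 nM in this assay. The step between them, ((hydroxycarbamoyl)methyl in place of hydroxycarbamoyl on a saturated chain carbon, five bonds along the chain from an aromatic nitrogen), gave an at least 7.5-fold lower number from compound 1 to compound 2 (0.87 log units; beyond the scatter), a reading that rests on (the limit of > 150000 nM in this assay, at which 1 of the 3 values shown sits).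

Compound 3 `Nc1nc2cc(-c3nn(CCCCC(=O)NO)c4ncnc(N)c34)ccc2o1` carries a different core; the difference between the two cores is not broken down here. In this assay compound 3 gives 14000 nM, and against compound 2 the two values lie within the scatter of each other.

Compound 4 `Nc1nc2cc(-c3nn(CCCCCC(=O)NO)c4ncnc(N)c34)ccc2o1` has not yet been measured. It differs from compound 3 by (hydroxycarbamoyl)methyl in place of hydroxycarbamoyl on a saturated chain carbon, four bonds along the chain from an aromatic nitrogen. For the measured compounds named here, this is the same kind of change as the one from compound 1 to compound 2, but not the same: there the place was five bonds along the chain from an aromatic nitrogen, here it is four bonds along the chain from an aromatic nitrogen. Going by the values given here, the one measured instance of this kind of change, from compound 1 to compound 2, gave an at least 7.5-fold lower number from compound 1 to compound 2 (0.87 log units; beyond the scatter). On that single step alone, read with caution, compound 4 is expected to show a 2.0-fold lower number from compound 3 to compound 4 (0.30 log units; within the scatter). Compound 4 is therefore estimated to give about 7000 nM in this assay, with a range from 2000 nM to 40000 nM.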

Compound 4, half-maximal inhibitory concentration: 12400 nM
Compound 4: the middle estimate sits 1.8-fold (0.25 log units) below what was measured; the range from low to high includes it.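

On the second core, the same lengthening of the tail gave a 1.1-fold lower number from compound 3 to compound 4 (0.05 log units; within the scatter), so in this assay the clear gain seen on the first core did not carry over. The change therefore cannot be treated as a step of fixed size across these two cores, although the comparison does not show whether the core itself or the place of the change, five bonds along the chain in one case and four in the other, sets the two steps apart: the same change on two cores in this assay, an at least 7.5-fold lower number (0.87 log units; beyond the scatter) from compound 1 to compound 2 and a 1.1-fold lower number (0.05 log units; within the scatter) from compound 3 to compound 4, at least 6.7-fold (0.82 log units) apart, beyond the scatter of two such steps The size of the first step is also only a bound, since compound 1 is reported only as a limit of the assay and not as a number: the limit of > 150000 nM in this assay, at which 1 of the 4 values shown sits.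

The compounds shown leave open how the core of compound 1 would respond to the same change made four bonds along the chain from an aromatic nitrogen, which would separate the effect of the core from that of the place. They also leave open whether a longer chain on the core of compound 3 would lower the number in this assay, and whether a carboxylic acid in place of the hydroxycarbamoyl group would give any reading there.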